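The compounds below may be only part of what the source reports. "The series", "measured", "known", "first", "only" and "open" are said of these compounds alone.

Measured so far:
- compound 1 `CCc1ccnc(O[C@@H]2CC[C@@H](C)N(C(=O)c3ccccc3-n3nccn3)C2)c1`: 0.6 nM
- compound 2 `C[C@@H]1CC[C@@H](Oc2cc(-c3ccccc3)ccn2)CN1C(=O)c1ccccc1-n1nccn1`: 3.8 nM

In an assay on CHO-K1 cells for displacement of a labelled ligand from Orexin receptor type 2 (Homo sapiens), read by radioligand binding (a higher number here means a weaker inhibitor, a lower number a stronger inhibitor), compound 2 gives the highest of the two numbers; the nearest is compound 1, which sits at 0.6 nM. Within the data shown here, the one measured step is a 6.3-fold higher number from compound 1 to compound 2 (0.80 log units; beyond the scatter), a change at the same aromatic carbon that is changed again here. Compound 3 `C[C@@H]1CC[C@@H](Oc2ccccn2)CN1C(=O)c1ccccc1-n1nccn1` is made from compound 2 by the change (hydrogen in place of phenyl on an aromatic carbon), so that the group on this carbon, meta to a large group and opposite the ring nitrogen, is removed altogether. Among the measured compounds shown here, nothing measured here shows what a bare hydrogen at this carbon does; the only guide is that the smaller ethyl group gave a lower number than phenyl. Because compound 1 stands at 0.6 nM, a modest lowering is possible, but a number close to compound 2 is equally plausible. Compound 3 is therefore expected at 5 nM, within 1.5 nM to 20 nM, a step of a 1.3-fold higher number from compound 2 to compound 3 (0.12 log units; within the scatter) that is expected to stay within the scatter.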

Compound 3, inhibition constant: 2400 nM
The estimate for compound 3 lay 480-fold (2.68 log units) below the measured number; measured number outside the range, above it.
By their numbers in this assay, from the lowest: compound 1; then compound 2; then compound 3.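

In this assay the group on this aromatic carbon, opposite the ring nitrogen, matters far more than the first pair could show: hydrogen in place of phenyl gives a 630-fold higher number from compound 2 to compound 3 (2.80 log units; beyond the scatter) and hydrogen in place of ethyl gives a 4000-fold higher number from compound 1 to compound 3 (3.60 log units; beyond the scatter) as the larger of the two jumps. Both steps far exceed a 6.3-fold higher number from compound 1 to compound 2 (0.80 log units; beyond the scatter) as a change, so the difference between ethyl and phenyl is minor compared with the difference between either group and hydrogen. Among these three compounds, having one of these carbon groups here counts for much more than which one it is, and no outside measurement bears on why.

Still open, from the compounds shown here alone, is whether a single methyl would restore most of the lost binding, or whether a longer chain such as propyl or a methoxy would match ethyl. The compounds shown also cannot say whether an amine on this carbon would be tolerated.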